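The compounds below may be only part of what the source reports. "The series", "measured", "known", "first", "only" and "open" are said of these compounds alone.

Three compounds have been measured in an ADME assay on HCT-116 cells (Homo sapiens) for cytotoxicity, read by CellTiter-Glo, with a stated time of 72 h; a higher number here means a weaker inhibitor, a lower number a stronger inhibitor:
compound 1 `CC1CCN(C2CCN(S(=O)(=O)c3cccc(Br)c3)CC2)CC1` gives > 5000 nM, a limit of the assay rather than a number.
compound 2 `Cc1noc(C)c1S(=O)(=O)N1CCC(N2CCC(C)CC2)CC1` gives > 10000 nM, also a limit.
compound 3 `CC1CCN(C2CCN(S(=O)(=O)c3ccc(Cl)c(Cl)c3)CC2)CC1` gives > 5000 nM, again a limit.

Compound 3 therefore stands at the limit of > 5000 nM in this assay, at which 2 of the 3 values shown sit; no number of its own is known for it, only that its potency lies past that limit. The new compound 4 `CC1CCN(C2CCN(S(=O)(=O)c3ccc(Br)c(Cl)c3)CC2)CC1` differs from compound 3 in one place: bromo in place of chloro on an aromatic carbon. Three measured steps exist, a step that the two limits leave unreadable from compound 1 to compound 2, a step that the two limits leave unreadable from compound 1 to compound 3 and a step that the two limits leave unreadable from compound 2 to compound 3, but each joins two limits, so none of them can be read as a size, and none of them exchanges bromo for chloro on an aromatic carbon. Within the data shown here, the only compound already carrying a bromo group is compound 1, and its reading is likewise a limit. With no readable step to lean on, the expected change is a step that the limit leaves unreadable from compound 3 to compound 4, which amounts to nothing beyond the usual scatter. Compound 4 is therefore estimated at 8000 nM, within 3000 nM to 30000 nM, and it is expected most likely to be reported as a limit once more.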

Compound 4, half-maximal inhibitory concentration: > 5000 nM
Compound 4: only a limit was reported; the forecaster's own chance of this, stated with the estimate: 85%; the middle value lies beyond the limit too.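

Compound 4 also ends at a limit rather than a number: the limit of > 5000 nM in this assay, at which 3 of the 4 values shown sit. Its steps from compound 1, compound 2 and compound 3 each join two limits, so none of them can be read as a size. The compounds shown leave open how potent any of them is, and whether bromo in place of chloro changes potency at all.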